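Aryl urea swap from compound 2 to compound 3

The source may hold more compounds than are shown below. What is called first, only, known or untested is meant among the compounds shown, and "the series" means these compounds.

In a functional assay on CCRF-CEM cells (Homo sapiens) for inhibition, read by MTT assay, with a stated time of 72 h (on this read-out higher numbers stand for weaker inhibition and lower numbers for stronger inhibition), compound 1 `COc1cc(NC(C)CCCNC(=O)NNC(=O)Nc2cc(C(F)(F)F)cc(C(F)(F)F)c2)c2ncccc2c1` gives 13000 nM and compound 2 `COc1cc(NC(C)CCCNC(=O)Nc2ccc(C(F)(F)F)cc2)c2ncccc2c1` gives 14000 nM; the two numbers fall within the usual scatter of each other, so neither stands apart. Compound 3 `COc1cc(NC(C)CCCNC(=O)Nc2cccc(F)c2)c2ncccc2c1` awaits measurement. It differs from compound 2 in one place: 3-fluorophenyl in place of 4-(trifluoromethyl)phenyl on an amide-type nitrogen. For the measured compounds named here, no measured pair carries this change, so no step size is known from the series; with both measured numbers sitting high in this assay, no movement beyond the scatter is expected. The estimate for compound 3 is 16000 nM, between 5000 nM and 50000 nM. The expected step is a 1.1-fold higher number from compound 2 to compound 3 (0.06 log units; within the scatter).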

Compound 3, half-maximal inhibitory concentration: 21000 nM
Estimate against measurement, compound 3: 1.3-fold (0.12 log units) below, within the range that was stated.
By their numbers in this assay, from the lowest: compounds 1, 2 and 3 (each within the scatter of the next).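

In this assay, 3-fluorophenyl in place of 4-(trifluoromethyl)phenyl on the amide-type nitrogen gives a 1.5-fold higher number from compound 2 to compound 3 (0.18 log units; within the scatter) and so stays within the scatter. This one pair therefore shows that the aryl group at this position can lose the trifluoromethyl group and take a fluorine elsewhere on the ring with no reading beyond the scatter. Nothing available bears on why this exchange leaves the number there.

Open, going by these compounds, is whether a carboxylic acid or an amine on this aryl ring would move the number beyond the scatter. On these data alone, a longer chain on this nitrogen, in place of the aryl group, remains equally open.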